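The source may report more compounds than this note shows. Statements on the series, on what has been measured and on what is new or still open speak of the compounds shown alone.

Compound 1 `CCN(CC)CCNC(=O)c1ccc(C(CC)(CC)c2ccc(OCSC)c(C)c2)n1CC` gives 5160 nM in a functional assay on MCF7 cells (Homo sapiens) for antiproliferative activity, read by MTT assay, with a stated time of 24 h; on this read-out higher numbers stand for weaker inhibition and lower numbers for stronger inhibition. Compound 2 `CCN(CC)CCNC(=O)c1ccc(C(CC)(CC)c2ccc(OCSc3ccccc3)c(C)c2)n1CC`, which differs from it by phenyl in place of methyl on a sulfur, gives 4900 nM, so that the step of a 1.1-fold lower number from compound 1 to compound 2 (0.02 log units; within the scatter) is the measured effect of this change. Compound 3 `CCN(CC)CCNC(=O)c1cc(C(CC)(CC)c2ccc(OCSC)c(C)c2)cn1CC` carries a different core; the difference between the two cores is not broken down here. In this assay compound 3 gives 4640 nM, and its values and those of compound 1 and compound 2 all sit close together. Compound 4 `CCN(CC)CCNC(=O)c1cc(C(CC)(CC)c2ccc(OCSc3ccccc3)c(C)c2)cn1CC` differs from compound 3 by phenyl in place of methyl on a sulfur, the same change at the same place as between compound 1 and compound 2. The step from compound 3 to compound 4 is expected to be a 1.1-fold lower number from compound 3 to compound 4 (0.03 log units; within the scatter), because the earlier step of a 1.1-fold lower number from compound 1 to compound 2 (0.02 log units; within the scatter) was small. Compound 4 is therefore estimated at 4300 nM, between 2500 nM and 7500 nM.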

Compound 4, half-maximal inhibitory concentration in the MCF7 assay: 4700 nM
Compound 4: middle estimate off by 1.1-fold (0.04 log units), on the low side, and the stated range covers the measured number.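

In the MCF7 assay the change of methyl to phenyl on the sulfur gives a 1.0-fold higher number from compound 3 to compound 4 (0.01 log units; within the scatter), and it reads the same on both cores: the same change on two cores in the MCF7 assay, a 1.1-fold lower number (0.02 log units; within the scatter) from compound 1 to compound 2 and a 1.0-fold higher number (0.01 log units; within the scatter) from compound 3 to compound 4, 1.1-fold (0.03 log units) apart, within the scatter of two such steps. The change does not leave every read-out flat, however: in a physicochemical assay for solubility, read by HPLC, at pH 7.4 (a higher number here means a more soluble compound, a lower number a less soluble compound), compound 3 gives 198 ug/mL and compound 4 gives 0.6 ug/mL. In the physicochemical assay the large drop is seen on one core only: the measured solubility of compound 3, 198 ug/mL, and of compound 4, 0.6 ug/mL, a 330-fold lower number (2.52 log units; beyond the scatter). Going by these compounds alone, the two small steps show only that the change leaves the antiproliferative number flat on these two cores, not that a larger effect would carry from one core to the other. The compounds shown leave open whether a longer chain or a benzyl group on the sulfur would move the number in the MCF7 assay at all. They also leave open whether the step in the physicochemical assay recurs on the core of compound 1.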